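The source may report more compounds than this note shows. Statements on the series, on what has been measured and on what is new or still open speak of the compounds shown alone.

Measured compounds:
Compound 1 `COc1ccc(C2=NN(C3=NC(=O)/C(=C4\C(=O)Nc5ccccc54)S3)C(c3ccc(OC)cc3)C2)cc1` gives 100000 nM in a functional assay on cells (Cancer cell lines, Homo sapiens) for cytotoxicity, read by sulforhodamine B assay, with a stated time of 48 h; on this read-out lower numbers stand for stronger inhibition of growth and higher numbers for weaker inhibition of growth.
Compound 2 `COc1ccc(C2=NN(C3=NC(=O)/C(=C4\C(=O)Nc5ccc(Br)cc54)S3)C(c3ccc(OC)cc3)C2)cc1` gives 32500 nM in this assay.
Compound 3 `CN(C)c1ccc(C2CC(c3ccccc3)=NN2C2=NC(=O)/C(=C3\C(=O)Nc4ccccc43)S2)cc1` gives 39700 nM in this assay.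

Compound 1 and compound 2 share a core and differ in one place: bromo in place of hydrogen on an aromatic carbon
That change brought a 3.1-fold lower number from compound 1 to compound 2 (0.49 log units; beyond the scatter). Compound 3 carries a different core; how it differs from compound 1 is not broken down here. Its value and that of compound 2 lie within the scatter of each other, while its number is lower than that of compound 1.

Compound 4 `CN(C)c1ccc(C2CC(c3ccccc3)=NN2C2=NC(=O)/C(=C3\C(=O)Nc4ccc(Br)cc43)S2)cc1` has not been measured in this assay. It relates to compound 3 as compound 2 relates to compound 1: bromo in place of hydrogen on an aromatic carbon
The place of the change reads the same in both pairs, so this is the same change applied to the second core. If it acts on compound 3 as it did on compound 1, the expected step is a 2.8-fold lower number from compound 3 to compound 4 (0.45 log units; beyond the scatter), beside a 3.1-fold lower number from compound 1 to compound 2 (0.49 log units; beyond the scatter) measured earlier; this rests on that single earlier step alone, since no other pair shows the change. The estimate for compound 4 is 14000 nM, with a likely range from 6000 nM to 35000 nM.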

Compound 4, concentration for total growth inhibition: 690 nM
Beside the measured number, compound 4's estimate is 20-fold (1.31 log units) above it, outside the stated range (below it).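

In this assay, bromo in place of hydrogen on an aromatic carbon again lowered the number on the second core, giving a 58-fold lower number from compound 3 to compound 4 (1.76 log units; beyond the scatter), so the direction of the step held on both cores shown. The size of the step did not carry over, and the gap between the two steps is too wide to put down to scatter: the same change on two cores in this assay, a 3.1-fold lower number (0.49 log units; beyond the scatter) from compound 1 to compound 2 and a 58-fold lower number (1.76 log units; beyond the scatter) from compound 3 to compound 4, 19-fold (1.27 log units) apart, beyond the scatter of two such steps The change can therefore be carried between these two cores as to direction but not as to size, although two pairs cannot show how it would behave on any further core, nor which difference between the cores goes with the gap.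

The compounds shown leave open whether a chloro or a nitro group on the same aromatic carbon would follow the bromo on either core. They also leave open whether the larger step goes with the dimethylamino group of compound 3 or with another part of its core.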